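The source may hold more compounds than are shown below. What is called first, only, known or untested is meant among the compounds shown, and "the series" means these compounds.

Compound 2, `CC(C)=CC[C@@H](OC(=O)C1CCCO1)C1=CC(=O)c2c(O)ccc(O)c2C1=O`, gives in a functional assay on HeLa cells (Homo sapiens) for cytotoxicity, read by MTT assay (on this read-out higher numbers stand for weaker inhibition and lower numbers for stronger inhibition), a value of 17000 nM. Among the two compounds measured so far it carries the lowest number, yet its only neighbour, compound 1, `CC(C)=CC[C@@H](OC[C@@H](C)O)C1=CC(=O)c2c(O)ccc(O)c2C1=O`, gives 22500 nM, and the step of a 1.3-fold lower number from compound 1 to compound 2 (0.12 log units; within the scatter) lies within the scatter, so the two are not separable. Compound 3, `CCCCCCC(C)(O)CC(=O)O[C@H](CC=C(C)C)C1=CC(=O)c2c(O)ccc(O)c2C1=O`, is the next compound in line. It differs from compound 2 at a single place: 2-hydroxy-2-methyloctyl in place of oxolan-2-yl on a carbonyl carbon. Among the compounds with values here, the only measured step, the one from compound 1 to compound 2, touches the same oxygen on the saturated carbon and was within the scatter, so it offers no sign that changes at this position move the numbers. Compound 3 is therefore expected to stay close to compound 2, with a step of a 1.1-fold lower number from compound 2 to compound 3 (0.05 log units; within the scatter), and is estimated at 15000 nM, within a range from 6000 nM to 40000 nM.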

Compound 3, half-maximal inhibitory concentration: > 100000 nM
Compound 3 gave a limit, no number; the forecaster's own chance of this, stated with the estimate: 5%; middle value at least 6.6-fold (0.82 log units) away from the limit.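

In this assay, 2-hydroxy-2-methyloctyl in place of oxolan-2-yl on the carbonyl carbon gives an at least 5.8-fold higher number from compound 2 to compound 3 (0.76 log units; beyond the scatter), so changes at this position can move the read-out, which a 1.3-fold lower number from compound 1 to compound 2 (0.12 log units; within the scatter) did not show. Going by these compounds, the result for compound 3 is a limit and not a number, so the full size of the step is unknown: the limit of > 100000 nM in this assay, at which 1 of the 3 values shown sits. This single change removes the five-membered ring, brings in an open chain and goes from 0 to 1 hydrogen-bond donor, so these differences arrive together.

The compounds shown do not separate the loss of the ring, the length of the chain and the hydroxy group as sources of the step. They also leave open how a shorter alkyl chain, or an amine, on the same carbonyl carbon would read in this assay.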